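The compounds below may be only part of what the source reports. "The series", "measured", "known", "first", "only" and "open" are said of these compounds alone.

Measured in a functional assay (blood) for inhibition, with Homo sapiens as the target; a lower number here means a stronger inhibitor, a higher number a weaker inhibitor:
- compound 1 `CC(C)(C)Sc1c(CC(C)(C)C(=O)O)n(Cc2ccc(Cl)cc2)c2ccc(OCc3ccc4cc(F)c(F)cc4n3)cc12`: > 3000 nM, a limit of the assay and not a number
- compound 2 `COc1ccc2nc(COc3ccc4c(c3)c(SC(C)(C)C)c(CC(C)(C)C(=O)O)n4Cc3ccc(Cl)cc3)sc2c1`: 670 nM
- compound 3 `CC(C)(C)Sc1c(CC(C)(C)C(=O)O)n(Cc2ccc(Cl)cc2)c2ccc(OCc3nc4ccccc4o3)cc12`: 2500 nM

Of the two compounds with a true number, compound 3 stands higher, at 2500 nM. Compound 4 `CC(C)(C)Sc1c(CC(C)(C)C(=O)O)n(Cc2ccc(Cl)cc2)c2ccc(OCc3ccncc3)cc12` differs from it as follows: pyridin-4-yl in place of 1,3-benzoxazol-2-yl on a saturated chain carbon bound to an oxygen on an aromatic ring. It carries pyridin-4-yl in place of 1,3-benzoxazol-2-yl. Two measured changes at this place bear on it: a 3.7-fold higher number from compound 2 to compound 3 (0.57 log units; beyond the scatter), and an at least 1.2-fold lower number from compound 1 to compound 3 (0.07 log units; that floor lies within the scatter). The largest measured change there is an at least 4.4-fold lower number from compound 1 to compound 2 (0.65 log units; beyond the scatter). Among the measured compounds shown here, none of the measured compounds carries a single-ring group at this place, so the direction is uncertain, and only a small rise in this assay is expected: a 1.2-fold higher number from compound 3 to compound 4 (0.08 log units; within the scatter). For compound 4 the estimated value is 3000 nM, with an expected range of 1000 nM to 8000 nM.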

Compound 4, half-maximal inhibitory concentration: > 3000 nM
Compound 4: a limit, no number; the forecaster's own chance of this, stated with the estimate: 40%; the middle value lies on the limit itself.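

In this assay the first single-ring group at this place, pyridin-4-yl, gives compound 4 only a limit of the assay, not a number: the limit of > 3000 nM in this assay, at which 2 of the 4 values shown sit.

The change from 6-methoxy-1,3-benzothiazol-2-yl gives an at least 4.4-fold higher number from compound 2 to compound 4 (0.65 log units; beyond the scatter), while the change from 1,3-benzoxazol-2-yl gives an at least 1.2-fold higher number from compound 3 to compound 4 (0.07 log units; that floor lies within the scatter), so that change has no readable direction. The step from compound 1 to compound 4 cannot be read.

The compounds shown leave open whether 1,3-benzothiazol-2-yl without its methoxy group would hold the gain seen in compound 2. As far as these compounds go, how a phenyl ring or an amine would read at this place also remains open.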